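Replacing a chloroethenyl with a hexyl on a deoxyuridine core

The source may report more compounds than this note shows. Statements on the series, on what has been measured and on what is new or still open speak of the compounds shown alone.

Of the compounds shown here, three have been tested in an ADME assay on L1210/0 cells (Mus musculus) for cytotoxicity, with a stated time of 48 h; a higher number here means a weaker inhibitor, a lower number a stronger inhibitor. Compound 1, `C=C(Cl)c1cn([C@H]2C[C@H](O)[C@@H](CO)O2)c(=O)[nH]c1=O`, is the only one to give a plain number: in this assay compound 1 gives 1660 nM. Compound 2, `O=c1[nH]c(=O)n([C@@H]2C[C@H](CO)C[C@@H]2CO)cc1I`, reaches only a limit of the assay, > 200000 nM. Compound 3, `CC(O)Cn1cnc2c(N)nc(I)nc21`, likewise stops at a limit, > 200000 nM. Compound 1 therefore stands alone as the one measurable inhibitor, while the other two are described only by the limit of > 200000 nM in this assay, at which 2 of the 3 values shown sit.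

Compound 4, `CCCCCCc1cn([C@H]2C[C@H](O)[C@@H](CO)O2)c(=O)[nH]c1=O`, shares the sugar and the pyrimidine core of compound 1 and differs in a single place: hexyl in place of 1-chloroethenyl on an aromatic carbon

Among the measured compounds shown here, no pair of measured compounds differs in only one place, so no measured step shows what such a swap does here. The change removes a small, double-bonded group and brings in a longer saturated chain. The expectation is that compound 4 becomes a weaker inhibitor than compound 1 by a margin well beyond the usual scatter, with the step of a 30-fold higher number from compound 1 to compound 4 (1.48 log units; beyond the scatter) expected in the direction of a higher number. In this assay compound 4 is estimated to give 50000 nM, with a plausible range from 8000 nM to 200000 nM.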

Compound 4, half-maximal inhibitory concentration: > 200000 nM
Compound 4: no number, only a limit; the forecaster's own chance of this, stated with the estimate: 25%; middle value at least 4.0-fold (0.60 log units) away from the limit.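

Among the compounds shown here, this is the first step that can be read as a single change on a shared core: in this assay, hexyl in place of 1-chloroethenyl on an aromatic carbon gives an at least 120-fold higher number from compound 1 to compound 4 (2.08 log units; beyond the scatter). Compound 4 gives > 200000 nM, which is a limit of the assay and not a number, so the step marks only the smallest possible size of the change. At this position, then, the two carbon-based groups are far from interchangeable, and the swap takes this core from a measurable value to the ceiling of the test: the limit of > 200000 nM in this assay, at which 3 of the 4 values shown sit.

The compounds shown leave open which part of the change matters most: the loss of the chlorine, the loss of the double bond, or the greater length of the chain. An ethyl or butyl chain, or a plain ethenyl group, at this same position on the same core could help tell these apart, and would show whether any saturated chain here keeps a measurable value.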